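Working notes: step from compound 3 to compound 4

A few compounds are considered here, and "the series" means these few. Any claim that something is new, unique, unknown or untested is made for them only; others in the source may bear on it.

Compound 3 `O=C(O)Cc1sc(C(c2ccc(F)cc2)c2ccc(F)cc2)nc1-c1cc(F)nc(F)c1` gives 80% in an in vitro functional assay on HEK285-7 cells for antagonist activity at prostaglandin D2 receptor 2 (Homo sapiens), read by BRET and beta-arrestin recruitment; a higher number here means a larger maximal response, a lower number a smaller maximal response. It stands level with compound 2 `O=C(O)Cc1sc(C(c2ccc(F)cc2)c2ccc(F)cc2)nc1-c1ccnc(F)c1`, which gives 80%; together these are the highest of the three numbers, and compound 1 `N#Cc1ccc(-c2nc(C(c3ccc(F)cc3)c3ccc(F)cc3)sc2CC(=O)O)cc1`, at 30%, lies furthest off. Compound 4 `O=C(O)Cc1sc(C(c2ccc(F)cc2)c2ccc(F)cc2)nc1-c1ccco1` differs from compound 3 by furan-2-yl in place of 2,6-difluoropyridin-4-yl on an aromatic carbon. The measured steps that bear on this alter the group at the same place: a number 50 percentage points higher from compound 1 to compound 2 (beyond the scatter) and a number 50 percentage points higher from compound 1 to compound 3 (beyond the scatter), both large, whereas no change at the digits printed from compound 2 to compound 3 (within the scatter). For the measured compounds named here, no measured step exchanges a six-membered ring for a five-membered one, so the direction remains open. For compound 4 the expected value is 55%, within 25% to 85%. The expected step is thus a number 25 percentage points lower from compound 3 to compound 4 (beyond the scatter), a moderate fall that could also turn out as no change.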

Compound 4, largest response reached (reported as efficacy), in percent of the reference or control that the assay uses: 80%
Compound 4: middle estimate off by 25 percentage points, on the low side; measured number inside the range.
By their numbers in this assay, from the lowest: compound 1; then compounds 2, 3 and 4 (each within the scatter of the next).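

In this assay, the aromatic carbon next to the ring nitrogen takes a five-membered aromatic ring as readily as a six-membered one: no change at the digits printed from compound 3 to compound 4 (within the scatter) for furan-2-yl in place of 2,6-difluoropyridin-4-yl, and no change at the digits printed from compound 2 to compound 4 (within the scatter) for furan-2-yl in place of 2-fluoropyridin-4-yl. Among these compounds only the 4-cyanophenyl of compound 1 stands apart, with a number 50 percentage points higher from compound 1 to compound 4 (beyond the scatter) on furan-2-yl replacing it. No measurement at hand accounts for this.

Open, from the compounds shown here alone, is whether an unsubstituted phenyl behaves like 4-cyanophenyl or like furan-2-yl. Also open, going by these compounds, is how an amine on the furan-2-yl ring, or a saturated piperidine ring at this place, would read.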